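A few compounds are considered here, and "the series" means these few. Any claim that something is new, unique, unknown or untested is made for them only; others in the source may bear on it.

Measured compounds:
compound 1 `C(=C/c1ccco1)\c1nc(NC2CC2)c2sccc2n1` — in a functional assay on L02 cells (Homo sapiens) for inhibition, read by Griess assay, with stated times of 1 h and 24 h (on this read-out higher numbers stand for weaker inhibition and lower numbers for stronger inhibition), reported as > 1000000 nM
compound 2 `CCN1CCN(c2nc(/C=C/c3cc(OC)c(OC)c(OC)c3)nc3ccsc23)CC1` — in this assay reported as > 1000000 nM

Both figures are limits of the assay rather than numbers. Compound 1 gives > 1000000 nM, a limit only. Compound 2 gives > 1000000 nM, also a limit. Where compound 2 stands is thus known only loosely: it sits at the limit of > 1000000 nM in this assay, at which 2 of the 2 values shown sit, and the one further value shown, that of compound 1, sits at the same limit. Among the measured compounds shown here, no step between two measured compounds can be drawn; the two compounds differ in several places and neither has a number.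

Compound 3 `COc1cc(/C=C/c2nc(NCc3ccccc3)c3sccc3n2)cc(OC)c1OC` differs from compound 2 in a single place: benzylamino in place of 4-ethylpiperazin-1-yl on an aromatic carbon. The data contain nothing that tells how such an exchange moves inhibition, and both measured compounds rest at the limit. The expected step is a number no higher from compound 2 to compound 3 (the limit leaves the size open), that is, none beyond the usual scatter. For compound 3 the estimate in this assay is 1000000 nM, with a range from 100000 nM to 10000000 nM, and it is expected that the assay will once more report only a limit.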

Compound 3, half-maximal inhibitory concentration: > 1000000 nM
Compound 3 gave a limit, no number; the forecaster's own chance of this, stated with the estimate: 75%; the middle value sits exactly at the limit.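

Among the compounds shown here, no step from compound 2 to compound 3 can be read in this assay because each compound gave only a limit, not a number: the limit of > 1000000 nM in this assay, at which 3 of the 3 values shown sit.

Going by these compounds, whether benzylamino in place of 4-ethylpiperazin-1-yl changes inhibition at all remains open, as does the true strength of all three compounds in this assay on this evidence.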